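A few compounds are considered here, and "the series" means these few. Any claim that something is new, unique, unknown or untested is made for them only; others in the source may bear on it.

Measured compounds:
Compound 1 `O=C(NCc1ccc(CNS(=O)(=O)c2ccccc2)cc1)c1ccc([N+](=O)[O-])cc1`: 100 nM
Compound 2 `Cc1ccc(S(=O)(=O)NCc2ccc(CNC(=O)c3ccc(Cl)cc3)cc2)cc1`: 10 nM
Compound 3 `O=C(NCc1ccc(CNS(=O)(=O)c2ccccc2)cc1)c1ccccc1Cl`: 10 nM

The measurement here is an assay on MDA-MB-231 cells for binding affinity to C-X-C chemokine receptor type 4 (Homo sapiens), read by immunofluorescence and microscopy, with stated times of 10 min and 30 min; on this read-out lower numbers stand for an effect already at smaller amounts and higher numbers for an effect only at larger amounts of compound. Compound 2 gives 10 nM, which is level with compound 3 at the digits shown and, together with compound 3, the lowest of the three numbers; compound 1 sits at 100 nM, a gap beyond the usual scatter.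

Compound 4 `Cc1ccc(S(=O)(=O)NCc2ccc(CNC(=O)c3cccc(Cl)c3)cc2)cc1` is made from compound 2 by 3-chlorophenyl in place of 4-chlorophenyl on a carbonyl carbon. The two compounds hold the same atoms, joined differently: the chlorine-bearing ring on the carbonyl carbon is rearranged, and nothing else moves.

For the measured compounds named here, only one measured step touches this carbonyl-side ring: a 10-fold lower number from compound 1 to compound 3 (1.00 log units; beyond the scatter), a modest gain. That step swaps the whole group, not just the chlorine's place, so it does not test the present change directly. Compounds 2 and 3, which carry 4-chlorophenyl and 2-chlorophenyl, show the same value at the digits printed, though they also differ elsewhere, so this is a hint rather than a clean comparison. On that basis the expected step in this assay is none beyond the scatter: no change at the digits printed from compound 2 to compound 4 (within the scatter). Compound 4 is therefore estimated at 10 nM, with a range from 4 nM to 30 nM.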

Compound 4, effective concentration (reported as EC, without a stated level of effect): 100 nM
Estimate against measurement, compound 4: 10-fold (1.00 log units) below; the measured number lies above the stated range.
By their numbers in this assay, from the lowest: compounds 2 and 3 (each within the scatter of the next); then compounds 1 and 4 (each within the scatter of the next).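

In this assay moving the chlorine alone gives a 10-fold higher number from compound 2 to compound 4 (1.00 log units; beyond the scatter) even though nothing else in the molecule changes. The earlier step from compound 1 to compound 3 replaced one whole group with another, so it could not show whether the place of a single atom on this ring matters; this pair shows that it does. The 4-chlorophenyl and 3-chlorophenyl groups match in every count available, including heavy atoms, hydrogen-bond donors and acceptors, and net charge, so those counts do not separate the two compounds, and no measurement available here accounts for the difference.

Going by these compounds, what happens with the 2-chlorophenyl group on the core of compound 2 remains open, as compound 3 carries that group but also differs from compound 2 in a second place. On these data alone, it is also open how this ring would behave if an amine or a carboxylic acid stood in place of the chlorine, so the result speaks only for the chlorine in these two places.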